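Cyano in place of methyl: what to expect

The source may hold more compounds than are shown below. What is called first, only, known or untested is meant among the compounds shown, and "the series" means these compounds.

Compound 1 `COC(=O)C1=C(C)N=C(C)/C(=C(/O)OC)C1c1cccc(OCc2nonc2C)c1`: 640 nM
Compound 2 `COC(=O)C1=C(C)N=C(C)/C(=C(/O)OC)C1c1ccccc1OCc1nonc1C`: 41 nM

Both numbers come from a functional assay (aorta) with Rattus norvegicus as the target, in the presence of a further agent that is not named here (on this read-out higher numbers stand for an effect only at larger amounts of compound and lower numbers for an effect already at smaller amounts), and the gap between them lies beyond the usual scatter of repeated measurements. Compound 2 has the lower number of the two (41 nM) and so acts at smaller amounts than compound 1 (640 nM) does.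

The next molecule is compound 3 `COC(=O)C1=C(C)N=C(C)/C(=C(/O)OC)C1c1ccccc1OCc1nonc1C#N` and it differs from compound 2 in a single group. The (4-methyl-1,2,5-oxadiazol-3-yl)methoxy of compound 2 becomes (4-cyano-1,2,5-oxadiazol-3-yl)methoxy in compound 3. The counted difference reads cyano in place of methyl on an aromatic carbon and the rest of the molecule stays the same.

Within the data shown here, no measured pair here shows a comparable single change, so this forecast has no direct precedent and remains uncertain. In this assay a small move towards a higher number is expected, probably not beyond the scatter. The estimated change is a 1.5-fold higher number from compound 2 to compound 3 (0.17 log units; within the scatter) and it may prove larger. For compound 3 the expected value is 60 nM with an estimated range from 15 nM to 250 nM for the measurement.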

Compound 3, half-maximal effective concentration: 6.6 nM
Compound 3: the middle estimate sits 9.1-fold (0.96 log units) above what was measured; measured number below the stated range.
By their numbers in this assay, from the lowest: compound 3; then compound 2; then compound 1.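

In this assay cyano in place of methyl gives a 6.2-fold lower number from compound 2 to compound 3 (0.79 log units; beyond the scatter) and so moves the effect to smaller amounts of compound. Compounds 1 and 2 both carry methyl on this aromatic carbon, so they could not show that a change here matters; compound 3 shows that this carbon, two ring bonds from the ring oxygen, is not a silent spot and that a single small swap can shift the read-out beyond the scatter. The swap adds only what the count shows, one more heavy atom with a triple bond and a hydrogen-bond acceptor, and nothing measured here says which of these features, if any, accounts for the step.

Going by these compounds, it remains open whether the gain is particular to the nitrile, or whether an amide, a carboxylic acid, an amine or a longer chain such as ethyl on the same carbon would move the number in the same direction. On these data alone, it is also open whether cyano would give a similar step with the side chain placed as in compound 1.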